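Aryl swaps on the piperazine nitrogen of an aminothiophene series

This account rests on a few compounds, and the source may have more. Where it says the series, first, only, none or still open, it means among the compounds named here.

Measured compounds:
- compound 1 `Nc1scc(CN2CCN(c3cc(Cl)cc(Cl)c3)CC2)c1C(=O)c1ccc(Cl)cc1`: -22%
- compound 2 `Nc1scc(CN2CCN(c3ccc(OC(F)(F)F)cc3)CC2)c1C(=O)c1ccc(Cl)cc1`: -13%
- compound 3 `Nc1scc(CN2CCN(c3cccnc3)CC2)c1C(=O)c1ccc(Cl)cc1`: 3.4%

In a functional assay on CHO cells with adenosine receptor A1 (Homo sapiens) as the target, read by cAMP accumulation and immunoassay, with a stated time of 6 min, tested at 0.1 uM (on this read-out higher numbers stand for a weaker effect at the one concentration tested and lower numbers for a stronger effect), compound 1 holds the lowest of the three numbers. Compound 2 gives a number within the scatter of it, a number 9 percentage points higher from compound 1 to compound 2 (within the scatter), while compound 3 sits beyond the scatter, a number 25.4 percentage points higher from compound 1 to compound 3 (beyond the scatter), and compound 3 is also beyond the scatter from compound 2, a number 16.4 percentage points higher from compound 2 to compound 3 (beyond the scatter). Compound 4 `Nc1scc(CN2CCN(c3cccc(F)c3)CC2)c1C(=O)c1ccc(Cl)cc1` is not yet measured; it differs from compound 1 as follows: 3-fluorophenyl in place of 3,5-dichlorophenyl on an amine nitrogen in a ring. Both measured steps replace the 3,5-dichlorophenyl, and the one keeping a carbon-only ring stayed within the scatter. For compound 4 a step of a number 10 percentage points higher from compound 1 to compound 4 (within the scatter) is therefore expected in this assay, most likely within the scatter. Compound 4 is estimated at -12%, range -28% to 5%.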

Compound 4, a percentage reported as activity, at one concentration (the size of the read-out at that concentration, not a potency): -37%
The estimate for compound 4 lay 25 percentage points above the measured number; the measured number lies below the stated range.
By their numbers in this assay, from the lowest: compound 4; then compounds 1 and 2 (each within the scatter of the next); then compound 3.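

In this assay a swap that keeps a carbon-only ring on this amine nitrogen can still move the number beyond the scatter: a number 15 percentage points lower from compound 1 to compound 4 (beyond the scatter). Among the compounds shown here, compound 4 also separates from the other two aryl variants, with a number 24 percentage points lower from compound 2 to compound 4 (beyond the scatter) and a number 40.4 percentage points lower from compound 3 to compound 4 (beyond the scatter), the latter the largest step at this position so far. No supporting data explain these steps.

Open, as far as these compounds go, is whether the shift tracks the kind of halogen or the number of halogens. A 3-chlorophenyl or 3,5-difluorophenyl group on the same nitrogen would separate the two.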